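The compounds below may be only part of what the source reports. "The series", "measured", "known", "first", "only" and "open" are said of these compounds alone.

Compounds measured so far in an assay on RBL-1 cells for inhibition of Polyunsaturated fatty acid 5-lipoxygenase (Rattus norvegicus); a higher number here means a weaker inhibitor, a lower number a stronger inhibitor: compound 1 `CN(O)/C=C\C(=O)c1ccc2ccccc2c1` gives 1800 nM; compound 2 `COc1ccc(C(=O)/C=C\N(C)O)cc1` gives 6000 nM; compound 3 `CCc1c(N(O)/C=C\C(=O)c2ccc3ccccc3c2)ccc2ccccc12` gives 750 nM.

On these numbers compound 1 stands second highest of the three: compound 3 sits lower than compound 1 by a gap beyond the scatter, and compound 2 sits higher than compound 1, also beyond the scatter. Compound 4 `O=C(/C=C\N(O)Cc1ccccc1)c1ccc2ccccc2c1` has not yet been measured in this assay. It differs from compound 1 in one place: phenyl in place of hydrogen on a saturated chain carbon bound to an amine nitrogen. Among the compounds with values here, no pair of measured compounds shows this exact change, so the size of the step is uncertain; since compound 3, which carries a larger group on the same nitrogen, gives 750 nM, a step toward a lower number is expected for compound 4, of moderate size, a 1.8-fold lower number from compound 1 to compound 4 (0.26 log units; within the scatter). The estimate for compound 4 is 1000 nM, with a range from 400 nM to 2500 nM.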

Compound 4, half-maximal inhibitory concentration: 1600 nM
Beside the measured number, compound 4's estimate is 1.6-fold (0.20 log units) below it; low and high end bracket the measured number.
By their numbers in this assay, from the lowest: compound 3; then compounds 4 and 1 (each within the scatter of the next); then compound 2.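

Phenyl in place of hydrogen on a saturated chain carbon bound to an amine nitrogen, the same difference as methyl to benzyl, brings a 1.1-fold lower number from compound 1 to compound 4 (0.05 log units; within the scatter) in this assay and lies within the scatter. Within the data shown here, this place on the core of compound 1 therefore holds a six-membered aromatic ring with no step that can be told from the scatter. Nothing measured here gives a reason for this result. Still open, going by these compounds, is whether a longer chain between the nitrogen and the phenyl, or an amine or a carboxylic acid on the phenyl, would give a step beyond the scatter.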